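Moving the ethyl group from 4-ethylphenyl to 3-ethylphenyl

The compounds below may be only part of what the source reports. "The series", "measured", "known", "first", "only" and "open" are said of these compounds alone.

- compound 1 `Cc1cccc(NS(=O)(=O)c2ccc(N3CCNC3=O)cc2)c1`: 69 nM
- compound 2 `O=C1NCCN1c1ccc(S(=O)(=O)Nc2ccc(F)cc2)cc1`: 230 nM
- compound 3 `CCc1ccc(NS(=O)(=O)c2ccc(N3CCNC3=O)cc2)cc1`: 480 nM

All three values come from a functional assay on M21 cells (Homo sapiens) for antiproliferative activity, read by sulforhodamine B assay, with a stated time of 48 h; on this read-out lower numbers stand for stronger inhibition and higher numbers for weaker inhibition. Compound 3 stands highest of the three at 480 nM. Compound 4 `CCc1cccc(NS(=O)(=O)c2ccc(N3CCNC3=O)cc2)c1` differs from it as follows: 3-ethylphenyl in place of 4-ethylphenyl on a sulfonamide nitrogen. Within the data shown here, no measured pair isolates this change. Among the measured compounds shown here, compound 1, the only measured compound with its group in a 3-substituted phenyl name, gives the lowest number at 69 nM. The steps away from it are a 7.0-fold higher number from compound 1 to compound 3 (0.84 log units; beyond the scatter) and a 3.3-fold higher number from compound 1 to compound 2 (0.52 log units; beyond the scatter). A modest move to a lower number in this assay is therefore expected, somewhat smaller than the first of these steps. The expected change is a 3.7-fold lower number from compound 3 to compound 4 (0.57 log units; beyond the scatter). Compound 4 is estimated at 130 nM, with an expected range of 45 nM to 380 nM.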

Compound 4, half-maximal inhibitory concentration: 82 nM
Compound 4: middle estimate off by 1.6-fold (0.20 log units), on the high side, within the range that was stated.
By their numbers in this assay, from the lowest: compounds 1 and 4 (each within the scatter of the next); then compound 2; then compound 3.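

In this assay, among these compounds, moving the ethyl group from 4-ethylphenyl to 3-ethylphenyl on the sulfonamide nitrogen gives a 5.9-fold lower number from compound 3 to compound 4 (0.77 log units; beyond the scatter), the first pair to isolate where the group sits while the group stays the same. The 3-ethylphenyl compound also differs from the 4-fluorophenyl compound, with a 2.8-fold lower number from compound 2 to compound 4 (0.45 log units; beyond the scatter), whereas the change from 3-methylphenyl to 3-ethylphenyl gives a 1.2-fold higher number from compound 1 to compound 4 (0.07 log units; within the scatter), so the two cannot be told apart. Nothing available explains this effect of position.

Still open, as far as these compounds go, is how a propyl chain, an amine or a carboxylic acid on this phenyl ring would read in this assay.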